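Replacing a Benzyloxy Group With Isobutyl on a Shared Core

A few compounds are considered here, and "the series" means these few. Any claim that something is new, unique, unknown or untested is made for them only; others in the source may bear on it.

The compounds here share one core and differ only in a single group on an aromatic carbon. Compound 1 `COCCOc1cc2oc(=O)n(CCC(=O)O)c2cc1Cl` and compound 2 `CCc1cc2oc(=O)n(CCC(=O)O)c2cc1Cl` have been tested in a physicochemical assay for permeability, using PAMPA; a higher number here means that the compound crosses the layer faster, a lower number that the compound crosses the layer more slowly. For compound 1 the result is a limit of this assay, < 3 nm/s. For compound 2 the result is also a limit of this assay, < 10 nm/s. The step that the two limits leave unreadable from compound 1 to compound 2 therefore cannot be read, because the limit of < 10 nm/s in this assay, at which 1 of the 3 values shown sits, and the limit of < 3 nm/s in this assay, at which 1 of the 3 values shown sits, mark only the edges of what the assay reports. Compound 3 `O=C(O)CCn1c(=O)oc2cc(OCc3ccccc3)c(Cl)cc21` gave "not determined" (no result reported) in this assay, so it stands at no number at all.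

Compound 4 `CC(C)Cc1cc2oc(=O)n(CCC(=O)O)c2cc1Cl` differs from compound 3 by isobutyl in place of benzyloxy on an aromatic carbon. No measured step bears directly on this change, and no step of readable size exists among these compounds. Compound 4 is thus expected to sit low, near the limits seen for compound 1 and compound 2, with an estimated permeability of 8 nm/s, ranging from 2 nm/s to 30 nm/s.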

Compound 4, apparent permeability: < 10 nm/s
Compound 4 was reported as a limit; the forecaster's own chance of this, stated with the estimate: 50%; the middle value does not contradict the limit.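

Among these compounds, compound 4, like compound 1 and compound 2, gives only a limit in this assay, and no step from either of them to compound 4 can be read. The compounds shown leave open how fast any of these compounds actually crosses the layer.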